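Bromo in place of methoxy: expecting compound 3

A few compounds are considered here, and "the series" means these few. Any claim that something is new, unique, unknown or untested is made for them only; others in the source may bear on it.

Compound 1 `O=S(=O)(c1ccccc1)c1nc2ccccc2nc1N1CCCC(O)C1` measures 3020 nM
Compound 2 `COc1ccc(S(=O)(=O)c2nc3ccccc3nc2N2CCCC(O)C2)cc1` measures 3050 nM

Both values come from a functional assay on HL-60 cells (Homo sapiens) for cytotoxicity, read by MTT assay, with a stated time of 72 h (on this read-out higher numbers stand for weaker inhibition and lower numbers for stronger inhibition), and lie within the scatter of each other, so compound 2 stands level with compound 1 on the numbers available. Not yet measured is compound 3 `O=S(=O)(c1ccc(Br)cc1)c1nc2ccccc2nc1N1CCCC(O)C1` which differs from compound 2 by bromo in place of methoxy on an aromatic carbon with bromo in place of methoxy on an aromatic carbon para to a large group.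

Going by the values given here, one measured step bears on this change, namely a 1.0-fold higher number from compound 1 to compound 2 (0.00 log units; within the scatter) for methoxy in place of hydrogen on an aromatic carbon. Compound 2 thus shows that adding the departing methoxy left the number within the scatter. Among the compounds with values here, no compound carrying bromo has been measured, and this single step is thin evidence for a new group. Nothing in these data points to a direction, and what is expected in this assay is a 1.1-fold lower number from compound 2 to compound 3 (0.05 log units; within the scatter) and so no step beyond the scatter. Compound 3 is expected at 2700 nM with an estimated range of 1100 nM to 6500 nM in this assay reading.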

Compound 3, half-maximal inhibitory concentration: 3430 nM
Estimate against measurement, compound 3: 1.3-fold (0.10 log units) below; the range from low to high includes it.
By their numbers in this assay, from the lowest: compounds 1, 2 and 3 (each within the scatter of the next).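

In this assay bromo in place of methoxy on this aromatic carbon, para to a large group, gives a 1.1-fold higher number from compound 2 to compound 3 (0.05 log units; within the scatter) and bromo in place of hydrogen gives a 1.1-fold higher number from compound 1 to compound 3 (0.06 log units; within the scatter) on the same ring. Until now only methoxy had been set against hydrogen here, and with bromo a second, different group stands level with both, so that hydrogen, methoxy and bromo all leave the number within the scatter of one another in this assay. No other evidence accompanies these values to say what lies behind this levelness.

What the three compounds leave open is whether any group at this place can move the number beyond the scatter, since an amine, a carboxylic acid or a longer chain here might behave differently from the three groups shown. They also leave open whether the same levelness would hold for changes made elsewhere on the shared core, where a step of a different size could still appear.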